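A Chloromethylphenyl Variant of the Weakest Thiazolidinone

The compounds below may be only part of what the source reports. "The series", "measured", "known", "first", "only" and "open" are said of these compounds alone.

Of the compounds shown here, three have been measured in a functional assay on MCF7 cells (Homo sapiens) for antiproliferative activity, read by MTT assay, with a stated time of 72 h; on this read-out lower numbers stand for stronger inhibition and higher numbers for weaker inhibition. Compound 1 `COc1ccc(/C=C2/CN(C)/C(=N/c3ccc(F)cc3)S2)cc1` gives 8000 nM, and compound 2 `COc1ccc(/C=C2/CN(C)/C(=N/c3ccc(OC)cc3)S2)cc1` gives 8700 nM. Among the measured compounds shown here, the only single-change step, a 1.1-fold higher number from compound 1 to compound 2 (0.04 log units; within the scatter), is too small to count as a real difference. Compound 3 `COc1ccc(/C=C2\S/C(=N\c3ccc(Cl)cc3)N(C)C2=O)cc1` is built on a different core than the other two; in this assay compound 3 gives 39300 nM, the highest number of the three and beyond the scatter from both of the others, so compound 3 is the weakest inhibitor measured here.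

Compound 4 `COc1ccc(/C=C2\S/C(=N\c3ccc(C)c(Cl)c3)N(C)C2=O)cc1` keeps the core of compound 3 and changes only the aromatic group on the double-bonded nitrogen: 3-chloro-4-methylphenyl in place of 4-chlorophenyl on a double-bonded nitrogen. For the measured compounds named here, no measured step covers this kind of change; the one step available, from fluoro to methoxy on compound 1 and compound 2, sits on the other core and stayed within the scatter. With no evidence for a shift in either direction, compound 4 is expected to stay close to compound 3, with a 1.1-fold lower number from compound 3 to compound 4 (0.05 log units; within the scatter). The estimate for compound 4 in this assay is 35000 nM, within a range from 12000 nM to 100000 nM.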

Compound 4, half-maximal inhibitory concentration: > 100000 nM
Compound 4 ended at the assay's limit; the forecaster's own chance of this, stated with the estimate: 15%; at least 2.8-fold (0.45 log units) between middle value and limit.
By their numbers in this assay, from the lowest: compounds 1 and 2 (each within the scatter of the next); then compound 3. At a limit, above all of these: compound 4.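

In this assay, the change on the core of compound 3 gives an at least 2.5-fold higher number from compound 3 to compound 4 (0.40 log units; beyond the scatter), so swapping the aromatic group on the double-bonded nitrogen can move the number beyond the scatter. Among the compounds shown here, on the other core, the one earlier step at this position stayed within the scatter, with a 1.1-fold higher number from compound 1 to compound 2 (0.04 log units; within the scatter), so the earlier compounds gave no sign of this; the two steps involve different groups, and neither alone shows how the cores compare. Compound 4 stands at a limit of the assay, so the step gives only a minimum size: the limit of > 100000 nM in this assay, at which 1 of the 4 values shown sits.

Because 3-chloro-4-methylphenyl differs from 4-chlorophenyl in two ways at once, the compounds shown cannot tell how much of the step belongs to the methyl and how much to the new chloro position; a 3-chlorophenyl or 4-methylphenyl group on this core would separate them. From the compounds shown here alone, whether a phenyl group carrying an amine or a carboxylic acid would give a lower number here also remains open.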